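Aryl swap at the ring nitrogen of the shared core

The source may report more compounds than this note shows. Statements on the series, on what has been measured and on what is new or still open speak of the compounds shown alone.

In a functional assay on B16-F10 cells (Mus musculus) for inhibition, read by MTT assay, with a stated time of 72 h (a higher number here means a weaker inhibitor, a lower number a stronger inhibitor), compound 2 `COc1ccc(Nc2nc(SCc3cn(Cc4ccccc4Cl)nn3)nc(-c3ccccc3)c2C#N)cc1` gives 3990 nM, the lowest of the two numbers at hand. Compound 1 `C#CCSc1nc(Nc2ccc(OC)cc2)c(C#N)c(-c2ccccc2)n1` gives 9710 nM; its gap to compound 2 lies beyond the scatter. Compound 3 `N#Cc1c(Nc2cccc(C(F)(F)F)c2)nc(SCc2cn(Cc3ccccc3Cl)nn2)nc1-c1ccccc1` is not yet measured. It differs from compound 2 in one place: 3-(trifluoromethyl)phenyl in place of 4-methoxyphenyl on a nitrogen on an aromatic ring. Going by the values given here, no measured pair shows this change, so there is nothing to anchor its size; a step within the scatter, in either direction, is the default expectation. For compound 3 the estimate is therefore 3500 nM, with a range from 1200 nM to 11000 nM. The expected step is a 1.1-fold lower number from compound 2 to compound 3 (0.06 log units; within the scatter).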

Compound 3, half-maximal inhibitory concentration: 3710 nM
Compound 3: middle estimate off by 1.1-fold (0.03 log units), on the low side; the measured number falls inside the stated range.
By their numbers in this assay, from the lowest: compounds 3 and 2 (each within the scatter of the next); then compound 1.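

Going by these compounds alone, this is the first reading at this place, on a nitrogen on an aromatic ring: a 1.1-fold lower number from compound 2 to compound 3 (0.03 log units; within the scatter) in this assay when 3-(trifluoromethyl)phenyl stands in place of 4-methoxyphenyl. The two aryl groups thus read alike here, so the hydrogen-bond acceptor counted on 4-methoxyphenyl is not required to keep the number at this level. No measurement at hand offers an explanation for this.

On these data alone, whether an amine or a carboxylic acid on this phenyl ring would move the number remains open. Also open, as far as these compounds go, is whether an alkyl chain in place of the ring would do so.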